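A few compounds are considered here, and "the series" means these few. Any claim that something is new, unique, unknown or untested is made for them only; others in the source may bear on it.

Working notes on the series. The series is tested in a functional assay on the whole organism (blood) with Rattus norvegicus as the target, with stated times of 24 h and 1 h, at a dose of 5 mg/kg by the intraperitoneal route (on this read-out lower numbers stand for a weaker effect and higher numbers for a stronger effect at the one dose given), where every compound is taken at one dose and the read-out gives the size of the effect at that dose. Compound 1 has the structure `COc1ncccc1C(=O)NCCC1CCN(S(=O)(=O)NC(=O)NC2CCCCC2)CC1` and in this assay compound 1 gives 33%. Compound 2 has the structure `Cc1cccc(C(=O)NCCC2CCN(S(=O)(=O)NC(=O)NC[C@@H]3C[C@@H]4C=C[C@@H]3C4)CC2)n1` and in this assay compound 2 gives 20%. Among the compounds with values here, of the two numbers known so far, compound 2 stands lowest; its nearest neighbour is compound 1, whose number lies higher by a gap that is beyond the usual scatter. Compound 1 and compound 2 differ from each other in more than one place, so their two values are set side by side without a step being drawn between them.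

The unmeasured compound 3 has the structure `O=C(NC[C@@H]1C[C@@H]2C=C[C@@H]1C2)NS(=O)(=O)N1CCC(CCNC(=O)c2cccc3cccnc23)CC1`. It arises from compound 2 by one change: quinolin-8-yl in place of 6-methylpyridin-2-yl on a carbonyl carbon. The (6-methylpyridin-2-yl)carbonyl of compound 2 thus becomes a (quinolin-8-yl)carbonyl in compound 3, with the amide-type nitrogen as the other neighbour of that carbonyl carbon unchanged.

Within the data shown here, no measured pair isolates this change, so there is no step to lean on. The expectation is therefore cautious: the step of a number 5 percentage points higher from compound 2 to compound 3 (within the scatter) is estimated to fall within the scatter, with no clear direction. Compound 3 is expected to give about 25% in this assay, estimated to lie between 8% and 45%.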

Compound 3, a percentage reported as activity, at one dose (the size of the read-out at that dose, not a potency): 34%
Beside the measured number, compound 3's estimate is 9 percentage points below it, and the stated range covers the measured number.
By their numbers in this assay, from the lowest: compound 2; then compounds 1 and 3 (each within the scatter of the next).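

In this assay, within the data shown here, the group on this carbonyl carbon proves able to move the read-out: quinolin-8-yl in place of 6-methylpyridin-2-yl gives a number 14 percentage points higher from compound 2 to compound 3 (beyond the scatter) and this modest change is the only step that can be read so far. The change takes the group from 7 to 10 heavy atoms and adds a six-membered aromatic ring of carbon only, while the counts of hydrogen-bond donors and acceptors stay the same, so the higher number goes with a larger aromatic group at unchanged counts. Nothing at hand bears on the reason for this step.

Among these compounds, the single step cannot separate the added ring from the loss of the methyl group, and pyridin-2-yl without the methyl, or naphthalen-1-yl with no ring nitrogen, would be the groups to pull those two apart. On these data alone, it also remains open whether the same exchange gives a similar step on the core of compound 1, and whether a saturated group such as cyclohexyl on this carbonyl carbon keeps any of the effect.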